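The compounds below may be only part of what the source reports. "The series", "measured", "known", "first", "only" and "open" are said of these compounds alone.

In a functional assay on A549 cells (Homo sapiens) for antiproliferative activity, read by MTT assay, with a stated time of 48 h (on this read-out higher numbers stand for weaker inhibition and lower numbers for stronger inhibition), compound 1 `CC(C)=CCC[C@]1(C)/C=C/[C@@H](OC(=O)C=C(C)C)[C@](C)(O)/C=C/C(=O)/C(C(=O)O)=C\C1` gives > 10000 nM, which is a limit of the assay and not a number. Compound 2 `CC(C)=CCC[C@]1(C)/C=C/[C@@H](OC(=O)C=C(C)C)[C@](C)(O)/C=C/C(=O)/C(CCl)=C\C1` gives 150 nM and compound 3 `COCOC/C1=C/C[C@](C)(CCC=C(C)C)/C=C/[C@@H](OC(=O)C=C(C)C)[C@](C)(O)/C=C/C1=O` gives 2980 nM, the higher of the two actual numbers. Next comes compound 4 `CC(C)=CCC[C@]1(C)/C=C/[C@@H](OC(=O)C=C(C)C)[C@](C)(O)/C=C/C(=O)/C(Cn2cc(CO)nn2)=C\C1`, with 4-(hydroxymethyl)-1H-1,2,3-triazol-1-yl in place of methoxymethoxy on a saturated chain carbon bound to a double-bonded ring carbon. Earlier changes in this part of the molecule were large or at least modest: a 20-fold higher number from compound 2 to compound 3 (1.30 log units; beyond the scatter), an at least 3.3-fold lower number from compound 1 to compound 3 (0.52 log units; beyond the scatter) and an at least 66-fold lower number from compound 1 to compound 2 (1.82 log units; beyond the scatter). None of these compounds carries the triazole, so they show that large steps are possible but give no direction, and no step beyond the scatter is expected. The expected change is a 1.5-fold lower number from compound 3 to compound 4 (0.17 log units; within the scatter). For compound 4 the estimated value is 2000 nM, with an expected range of 400 nM to 9000 nM.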

Compound 4, half-maximal inhibitory concentration: 3470 nM
Beside the measured number, compound 4's estimate is 1.7-fold (0.24 log units) below it, and the stated range covers the measured number.
By their numbers in this assay, from the lowest: compound 2; then compounds 3 and 4 (each within the scatter of the next). At a limit, above all of these: compound 1.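

In this assay, exchanging methoxymethoxy for 4-(hydroxymethyl)-1H-1,2,3-triazol-1-yl on this saturated chain carbon stays within the scatter: a 1.2-fold higher number from compound 3 to compound 4 (0.07 log units; within the scatter). Chloro remains clearly apart from this larger ring-bearing group, with a 23-fold higher number from compound 2 to compound 4 (1.36 log units; beyond the scatter). Replacing carboxy gives an at least 2.8-fold lower number from compound 1 to compound 4 (0.45 log units; beyond the scatter), a step that rests on a limit and not on a number: the limit of > 10000 nM in this assay, at which 1 of the 4 values shown sits.

Still open, on these data alone, is whether the low number of compound 2 is specific to chloro or is shared by bromo or an amine at this carbon. Also open, as far as these compounds go, is how the triazole series responds when a carboxylic acid or a longer chain replaces its hydroxymethyl.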